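Swapping the aryl group on a sulfonyl urea EP3 ligand

The compounds below may be only part of what the source reports. "The series", "measured", "known", "first", "only" and "open" are said of these compounds alone.

Measured compounds:
Compound 1, `O=C(NS(=O)(=O)c1cc(Cl)c(Cl)s1)OC/C=C1\CCCc2cnn(Cc3ccc(Cl)cc3Cl)c21`, 1 nM
Compound 2, `COc1ccc(Cl)cc1S(=O)(=O)NC(=O)NC/C=C1\CCCc2cnn(Cc3ccc(Cl)cc3Cl)c21`, 3 nM

Both compounds were tested in an assay on isolated protein for displacement of a labelled ligand from prostaglandin E2 receptor EP3 subtype (Homo sapiens), read by scintillation counting, with a stated time of 2 h; a higher number here means a weaker inhibitor, a lower number a stronger inhibitor. Compound 1 gives 1 nM. Compound 2 carries a urea linker in place of the carbamate of compound 1 and a different aryl group on the sulfonyl sulfur; in this assay compound 2 gives 3 nM. Of these two numbers, compound 2 has the higher one, and the gap to compound 1 lies beyond the usual scatter of this assay.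

Compound 3, `O=C(NC/C=C1\CCCc2cnn(Cc3ccc(Cl)cc3Cl)c21)NS(=O)(=O)c1ccc(Cl)cc1`, is not yet measured. It differs from compound 2 in one place: 4-chlorophenyl in place of 5-chloro-2-methoxyphenyl on a sulfonyl sulfur. The methoxy group is lost and the chlorine sits on a different position of the ring. Going by the values given here, no measured pair shows this change, so its size cannot be read from the data. The expectation is a modest move toward a higher number, a 3.3-fold higher number from compound 2 to compound 3 (0.52 log units; beyond the scatter), though a result within the scatter would not surprise. Compound 3 is estimated at 10 nM, with a likely range from 3 nM to 40 nM.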

Compound 3, inhibition constant: 4 nM
The estimate for compound 3 lay 2.5-fold (0.40 log units) above the measured number; measured number inside the range.
By their numbers in this assay, from the lowest: compound 1; then compounds 2 and 3 (each within the scatter of the next).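

In this assay, the change on the sulfonyl sulfur from 5-chloro-2-methoxyphenyl to 4-chlorophenyl gives a 1.3-fold higher number from compound 2 to compound 3 (0.12 log units; within the scatter). Going by these compounds alone, this is the first single-place comparison, and it shows that, with the urea linker in place, this swap of aryl groups leaves no difference that can be told from the usual scatter. The methoxy group is therefore not required for a low number here, but nothing measured explains this result.

On these data alone, the step removes the methoxy group and changes the chlorine's position together, so the share of each remains open, and a plain phenyl group would be one way to separate them. Also open, as far as these compounds go, are how an aryl group carrying an amine or a carboxylic acid would read, and how the urea compares with the carbamate when the aryl group is held constant.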